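The source may hold more compounds than are shown below. What is called first, only, known or untested is meant among the compounds shown, and "the series" means these compounds.

Measured compounds in an ADME assay on HepG2 2.2.15 cells (Homo sapiens) for cytotoxicity; on this read-out higher numbers stand for lower toxicity in this test and lower numbers for higher toxicity in this test:
- compound 1 `CC(C)C(=O)OCCc1c(-c2ccccc2Cl)c2cc(Cl)ccc2[nH]c1=O` gives 62000 nM
- compound 2 `O=C(COc1ccccc1)OCCc1c(-c2ccccc2Cl)c2cc(Cl)ccc2[nH]c1=O` gives 81000 nM
- compound 3 `O=C(CCOc1ccccc1)OCCc1c(-c2ccccc2Cl)c2cc(Cl)ccc2[nH]c1=O` gives 46000 nM

Compound 1 stands second highest of the three numbers in this assay, with compound 2 nearest (a 1.3-fold higher number from compound 1 to compound 2 (0.12 log units; within the scatter)) and compound 3 furthest (a 1.3-fold lower number from compound 1 to compound 3 (0.13 log units; within the scatter)); both steps lie within the scatter, as does the step between compound 2 and compound 3 (a 1.8-fold lower number from compound 2 to compound 3 (0.25 log units; within the scatter)).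

Compound 4 `O=C(/C=C/c1ccccc1)OCCc1c(-c2ccccc2Cl)c2cc(Cl)ccc2[nH]c1=O` has not yet been measured. It differs from compound 1 at the carbonyl carbon of the ester: 2-phenylethenyl in place of isopropyl on a carbonyl carbon

For the measured compounds named here, the steps that bear on this change are those from compound 1 to compound 2 and from compound 1 to compound 3, both of which also replace isopropyl with a larger carbon group carrying a six-membered aromatic ring, and neither moved this assay beyond the scatter. On that basis a step of a 1.1-fold lower number from compound 1 to compound 4 (0.05 log units; within the scatter) is expected, with no change beyond the scatter in either direction. The estimate for compound 4 in this assay is therefore 55000 nM, with a range from 25000 nM to 120000 nM.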

Compound 4, half-maximal cytotoxic concentration: 230000 nM
Compound 4: the middle estimate sits 4.2-fold (0.62 log units) below what was measured; measured number above the stated range.
By their numbers in this assay, from the lowest: compounds 3, 1 and 2 (each within the scatter of the next); then compound 4.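

In this assay the carbonyl carbon of the ester turned out to be a place where a change can move the number beyond the scatter, which no earlier change there had done: 2-phenylethenyl in place of isopropyl gives a 3.7-fold higher number from compound 1 to compound 4 (0.57 log units; beyond the scatter), towards lower toxicity in this test. Compounds 2 and 3 also carry a six-membered aromatic ring, yet 2-phenylethenyl in their place gives a 2.8-fold higher number from compound 2 to compound 4 (0.45 log units; beyond the scatter) and a 5.0-fold higher number from compound 3 to compound 4 (0.70 log units; beyond the scatter), so that ring alone does not go with the higher number. Nothing at hand accounts for this result.

The compounds shown leave open whether the double bond itself matters, which a saturated 2-phenylethyl group at the same carbonyl carbon would address. They also leave open how an amine or a carboxylic acid on the phenyl ring of the 2-phenylethenyl group would read in this assay.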